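The source may report more compounds than this note shows. Statements on the series, on what has been measured and on what is new or still open speak of the compounds shown alone.

Measured compounds:
Compound 1 `C=CCSc1nnc(-c2cc(OC)c(OC)c(OC)c2)n1N1C(=O)c2ccccc2C1=O`: in a functional assay on MKN-45 cells (Homo sapiens) for cytotoxicity, read by MTT assay, with a stated time of 48 h (a higher number here means a weaker inhibitor, a lower number a stronger inhibitor), compound 1 reaches only a limit, > 200000 nM.
Compound 2 `COc1cc(-c2nnc(SCC(=O)c3ccc(C)cc3)n2N2C(=O)c3ccccc3C2=O)cc(OC)c1OC`: in this assay compound 2 gives 9620 nM.

Going by the values given here, compound 2 carries the only actual number in this assay; the other value shown for the series is a limit. Compound 3 `COc1cc(-c2nnc(SC)n2N2C(=O)c3ccccc3C2=O)cc(OC)c1OC` differs from compound 2 by hydrogen in place of (4-methylphenyl)carbonyl on a saturated chain carbon bound to a sulfur. Among the compounds with values here, the single measured step that bears on this change is an at least 20-fold lower number from compound 1 to compound 2 (1.31 log units; beyond the scatter), which installed the same aryl carbonyl group at the same place, there replacing vinyl rather than hydrogen; its size is known only as a bound because of the limit of > 200000 nM in this assay, at which 1 of the 2 values shown sits. Taking the group away again is therefore expected to cost potency in this assay, and the step is estimated as large, a 10-fold higher number from compound 2 to compound 3 (1.02 log units; beyond the scatter), with a real chance that only a limit is reported. Compound 3 is accordingly expected at 100000 nM, in the range 20000 nM to 300000 nM.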

Compound 3, half-maximal inhibitory concentration: > 200000 nM
Compound 3 gave a limit, no number; the forecaster's own chance of this, stated with the estimate: 40%; at least 2.0-fold (0.30 log units) between middle value and limit.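

In this assay, hydrogen in place of (4-methylphenyl)carbonyl on a saturated chain carbon bound to a sulfur gives an at least 20-fold higher number from compound 2 to compound 3 (1.31 log units; beyond the scatter). The large effect of this group is therefore seen against two different partners, hydrogen as well as vinyl, and among the compounds shown, a measurable number appears only with (4-methylphenyl)carbonyl at this place. Hydrogen and vinyl cannot be ordered, since the step between compound 1 and compound 3 cannot be read and both values are limits: the limit of > 200000 nM in this assay, at which 2 of the 3 values shown sit.

Which part of (4-methylphenyl)carbonyl matters stays open: an acetyl group would test the carbonyl without the ring, and a 4-methylbenzyl group the ring without the carbonyl. Also open, as far as these compounds go, is how a carboxylic acid or an amine at this place would read out.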